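Swapping a Benzyl for a Sulfonyl on the Ring Nitrogen

This account rests on a few compounds, and the source may have more. Where it says the series, first, only, none or still open, it means among the compounds named here.

Compound 1 `COc1ccc(-c2cc(=O)c3c(OC)cc(OC)cc3n2Cc2ccccc2)cc1` was tested in a functional assay on KOPN-8 cells (Homo sapiens) for antiproliferative activity, with a stated time of 72 h; on this read-out higher numbers stand for an effect only at larger amounts of compound and lower numbers for an effect already at smaller amounts. Compound 1 gives only a limit there, > 17300 nM, so its true value is not pinned down. Compound 2 `COC(=O)c1cc(=O)c2c(OC)cc(OC)cc2[nH]1` likewise reaches only a limit, > 34400 nM. Compound 3 `COC(=O)c1cc(=O)c2c(OC)cc(OC)cc2n1S(=O)(=O)c1ccc(C)cc1` gives 6000 nM in this assay. Compound 4 `COc1ccc(-c2cc(=O)c3c(OC)cc(OC)cc3n2S(=O)(=O)c2ccc(Br)cc2)cc1` differs from compound 1 in one place: (4-bromophenyl)sulfonyl in place of benzyl on an aromatic nitrogen. Within the data shown here, no measured pair shows this exact change, so its size is uncertain; the contrast between compound 2 and compound 3 hints that a sulfonyl group on that nitrogen may go with a lower number. A step in that direction, an at least 2.1-fold lower number from compound 1 to compound 4 (0.33 log units; beyond the scatter), is expected for compound 4, likely beyond the usual scatter if compound 1 sits near its limit. Compound 4 is estimated at 8000 nM, within 2000 nM to 40000 nM.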

Compound 4, half-maximal effective concentration: > 86200 nM
Compound 4: only a limit was reported (the forecaster's own chance of this, stated with the estimate: 35%); middle value at least 10-fold (1.03 log units) from the limit.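

Compound 1 and compound 4 each give only a limit, so the step between them cannot be read. The compounds shown leave open whether (4-bromophenyl)sulfonyl in place of benzyl on an aromatic nitrogen changes the result in this assay.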